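Trimming the amide acyl group in an H3 ligand series

This account rests on a few compounds, and the source may have more. Where it says the series, first, only, none or still open, it means among the compounds named here.

Within the data shown here, compound 1 `Cc1cc(N2CCC(N3CCCC3C)C2)ccc1NC(=O)C1C(C)(C)C1(C)C` is one of two compounds measured in an assay on CHO cells for displacement of a labelled ligand from histamine receptor H3 (Macaca mulatta) (a higher number here means a weaker inhibitor, a lower number a stronger inhibitor), and in it compound 1 gives 37.3 nM, the highest of the two numbers. Among the measured compounds shown here, its single-stereoisomer counterpart compound 2 `Cc1cc(N2CC[C@H](N3CCC[C@@H]3C)C2)ccc1NC(=O)C1C(C)(C)C1(C)C` gives 0.55 nM, and the step of a 68-fold lower number from compound 1 to compound 2 (1.83 log units; beyond the scatter) is the only measured step; the two compounds differ only in that (the fact that one of compounds 1 and 2 is drawn with a defined configuration and the other without, at the place where they differ). Compound 3 `Cc1cc(N2CCC(N3CCCC3C)C2)ccc1NC(=O)C1CC1` carries cyclopropyl in place of 2,2,3,3-tetramethylcyclopropyl on a carbonyl carbon. For the measured compounds named here, no measured step touches the acyl group, so the stereochemical step gives no direct guide to the size or direction of the change from compound 1 to compound 3, and the estimate rests on compound 1 alone with a wide margin. Compound 3 is expected to give about 150 nM in this assay, within a range of 20 nM to 1200 nM, which corresponds to an expected step of a 4.0-fold higher number from compound 1 to compound 3 (0.60 log units; beyond the scatter).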

Compound 3, inhibition constant: 9.6 nM
The estimate for compound 3 lay 16-fold (1.19 log units) above the measured number; the whole stated range lies above it.
By their numbers in this assay, from the lowest: compound 2; then compound 3; then compound 1.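

Replacing 2,2,3,3-tetramethylcyclopropyl with cyclopropyl on a carbonyl carbon gives a 3.9-fold lower number from compound 1 to compound 3 (0.59 log units; beyond the scatter) in this assay, so the ring substituents of compound 1 are not required for a number of this order. Among these compounds, the only earlier step concerned stereochemistry, whereas this one shows that the acyl group itself moves the number, and that here the group with fewer heavy atoms gives the lower value, although this rests on a single pair with the stereocentres undefined in both compounds. Nothing available explains why this change lowers the number.

The compounds shown leave open whether defining the stereocentres in compound 3 would lower its number as it does for compound 1. They also leave open how 2,2-dimethylcyclopropyl, cyclobutyl or an open chain such as isopropyl would behave on the same carbonyl carbon.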